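Methoxy for amino in a nucleoside series: growth inhibition notes

The compounds below may be only part of what the source reports. "The series", "measured", "known", "first", "only" and "open" are said of these compounds alone.

Measured compounds in a functional assay on K562 cells (Homo sapiens), read by MTT assay, with a stated time of 72 h; on this read-out lower numbers stand for stronger inhibition and higher numbers for weaker inhibition:
- compound 1 `COc1nc(N)nc2c1c(-c1cccs1)cn2[C@@H]1O[C@H](CO)[C@@H](O)[C@H]1O`: compound 1 gives only the assay limit > 20000 nM.
- compound 2 `Nc1nc(N)c2c(-c3cccs3)cn([C@@H]3O[C@H](CO)[C@@H](O)[C@H]3O)c2n1`: compound 2 gives only the assay limit > 20000 nM.
- compound 3 `Nc1nc(N)c2c(-c3cc4ccccc4o3)cn([C@@H]3O[C@H](CO)[C@@H](O)[C@H]3O)c2n1`: compound 3 gives only the assay limit > 20000 nM.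

The change from compound 2 to compound 1 is methoxy in place of amino on an aromatic carbon. Its step in this assay is a step that the two limits leave unreadable from compound 2 to compound 1. The two cores differ as 1-benzofuran-2-yl in place of thiophen-2-yl on an aromatic carbon, with the step that the two limits leave unreadable from compound 2 to compound 3. Within the data shown here, every value shown is a limit, so no step in this set is readable, as the limit of > 20000 nM in this assay, at which 3 of the 3 values shown sit, records.

Compound 4 `COc1nc(N)nc2c1c(-c1cc3ccccc3o1)cn2[C@@H]1O[C@H](CO)[C@@H](O)[C@H]1O` is not yet measured. It differs from compound 3 as methoxy in place of amino on an aromatic carbon, the same change as from compound 2 to compound 1, since the two descriptions of the place agree word for word.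

For compound 4 the expected step from compound 3 is a step that the limit leaves unreadable from compound 3 to compound 4, an expectation resting on compound 3 at > 20000 nM and on the unreadable a step that the two limits leave unreadable from compound 2 to compound 1. Compound 4 is thus estimated at 30000 nM, most likely again only a limit, with a plausible range from 15000 nM to 100000 nM.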

Compound 4, half-maximal inhibitory concentration: 15500 nM
The estimate for compound 4 lay 1.9-fold (0.29 log units) above the measured number; the range from low to high includes it.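

In this assay, methoxy in place of amino, with 1-benzofuran-2-yl kept on the shared core, gives an at least 1.2-fold lower number from compound 3 to compound 4 (0.11 log units; that floor lies within the scatter), and 1-benzofuran-2-yl in place of thiophen-2-yl, with methoxy kept, gives an at least 1.2-fold lower number from compound 1 to compound 4 (0.11 log units; that floor lies within the scatter). Both floors lie within the scatter, so compound 4 having a number where its two neighbours have only limits does not establish a change of meaningful size from either one. The same methoxy change on the thiophen-2-yl compounds and all other steps cannot be read, so the data neither confirm nor refute that the change carries from one core to another, and the comparison is capped by the assay limit: the limit of > 20000 nM in this assay, at which 3 of the 4 values shown sit.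

On these data alone, it remains open how far compound 3 and compound 1 actually lie from compound 4, since only limits stand for them. Also open, as far as these compounds go, is whether ethoxy, a longer alkoxy chain or a carboxylic acid at the place of the methoxy group would give a number clearly apart from that of compound 4.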